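Moving the furan link on a weak growth inhibitor

The compounds below may be only part of what the source reports. "The series", "measured", "known", "first", "only" and "open" are said of these compounds alone.

Measured so far in a functional assay on HT-29 cells (Homo sapiens) for inhibition, read by colorimetric assay and sulforhodamine B assay, with a stated time of 48 h; a lower number here means a stronger inhibitor of growth, a higher number a weaker inhibitor of growth
compound 1 `CCCCCCCCCCCC[C@@H](O)[C@H]1CC[C@H]([C@H](O)CCCCCCCCCCNC(=O)c2cccs2)O1` gives 2190 nM
compound 2 `CCCCCCCCCCCC[C@@H](O)[C@H]1CC[C@H]([C@H](O)CCCCCCCCCCNC(=O)c2ccco2)O1` gives 100000 nM

Compound 2 stands highest of the two, making it the weaker growth inhibitor. Compound 3 `CCCCCCCCCCCC[C@@H](O)[C@H]1CC[C@H]([C@H](O)CCCCCCCCCCNC(=O)c2ccoc2)O1` differs from it in one place: furan-3-yl in place of furan-2-yl on a carbonyl carbon. Among the measured compounds shown here, the only measured step bearing on this is a 46-fold higher number from compound 1 to compound 2 (1.66 log units; beyond the scatter), a large one. For the measured compounds named here, it exchanged a different group, so it shows only that a change at this place can move the number strongly. The expected move is a 6.7-fold lower number from compound 2 to compound 3 (0.82 log units; beyond the scatter), toward a lower number, with its size quite uncertain. For compound 3 the estimated value is 15000 nM, with an expected range from 2000 nM to 100000 nM.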

Compound 3, concentration for 50% growth inhibition: 100000 nM
Compound 3: middle estimate off by 6.7-fold (0.82 log units), on the low side, and the stated range covers the measured number.
By their numbers in this assay, from the lowest: compound 1; then compounds 2 and 3 (each within the scatter of the next).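

In this assay, moving the link from furan-2-yl to furan-3-yl gives no change at the digits printed from compound 2 to compound 3 (within the scatter) at this place on the carbonyl carbon, so the point of attachment of the furan shows no effect here. The swap from thiophen-2-yl to the other furan gives a 46-fold higher number from compound 1 to compound 3 (1.66 log units; beyond the scatter) as well, so the large step seen earlier is not confined to furan-2-yl. No evidence here explains the gap between thiophen-2-yl and the two furans.
From the compounds shown here alone, whether thiophen-3-yl or a plain phenyl ring on the same carbonyl would keep the number of compound 1 remains open.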